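The compounds below may be only part of what the source reports. "The series", "measured", "known", "first", "only" and "open" are said of these compounds alone.

The series shares one core and varies only the group on the double-bonded nitrogen. Compound 1 `CCC/N=C(\NC#N)Nc1cccnc1` and compound 2 `CCCC/N=C(\NC#N)Nc1cccnc1` were tested in a functional assay on the whole organism (blood, strain Wistar-Okamoto) with Rattus norvegicus as the target, with a stated time of 5 days; a lower number here means that less compound is needed, a higher number that more compound is needed for the effect: compound 1 gives 20 mg/kg, and compound 2 gives 20 mg/kg, so that no change at the digits printed from compound 1 to compound 2 (within the scatter). Compound 3 `CCOCC/N=C(\NC#N)Nc1cccnc1` reached only a limit of this assay, giving > 20 mg/kg. The steps of a number no lower from compound 1 to compound 3 (the limit leaves the size open) and a number no lower from compound 2 to compound 3 (the limit leaves the size open) both rest on (the limit of > 20 mg/kg in this assay, at which 1 of the 3 values shown sits), so their size cannot be read. Compound 4 `N#CN/C(=N\c1ccccc1)Nc1cccnc1` differs from compound 3 by phenyl in place of 2-ethoxyethyl on a double-bonded nitrogen. Within the data shown here, no measured step touches a phenyl on this nitrogen; the known steps only show that lengthening the chain left the dose unchanged and that adding ethoxy gave a dose no lower than the chain compounds. The step of a number no higher from compound 3 to compound 4 (the limit leaves the size open) is therefore expected as a return to the level of the chain compounds rather than any readable size. Compound 4 is expected to give about 20 mg/kg, within 10 mg/kg to 40 mg/kg, with a real chance that only a limit is reported again.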

Compound 4, minimum effective dose: 5 mg/kg
Compound 4: the middle estimate sits 4.0-fold (0.60 log units) above what was measured, and the stated range ends above it.
By their numbers in this assay, from the lowest: compound 4; then compounds 1 and 2 (each within the scatter of the next).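

With phenyl on the double-bonded nitrogen, this assay shows for the first time that this position can lower the dose beyond the scatter, which the chain compounds had not shown. Phenyl in place of butyl gives a 4.0-fold lower number from compound 2 to compound 4 (0.60 log units; beyond the scatter), and phenyl in place of propyl gives a 4.0-fold lower number from compound 1 to compound 4 (0.60 log units; beyond the scatter). Phenyl in place of 2-ethoxyethyl gives an at least 4.0-fold lower number from compound 3 to compound 4 (0.60 log units; beyond the scatter), a step whose full size stays unknown: the limit of > 20 mg/kg in this assay, at which 1 of the 4 values shown sits.

The compounds shown do not tell whether the gain belongs to the aromatic ring itself or needs a ring of any kind, which a cyclohexyl group on the same nitrogen would separate. They also leave open how far the dose moves when the phenyl carries a further group, such as a chlorine or a methoxy.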